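Swapping the benzyl substituent on a triazine modulator of GPR68

This account rests on a few compounds, and the source may have more. Where it says the series, first, only, none or still open, it means among the compounds named here.

Compound 1 `CNc1nc(NCc2ccccc2)nc(-c2ccccc2CO)n1`: 4.51
Compound 2 `Nc1nc(NCc2ccc(F)cc2)nc(-c2ccccc2CO)n1`: 3.97

Of the compounds shown here, two sharing the same core have been tested so far. In a functional assay on cells for positive allosteric modulation of G-protein coupled receptor 68 (Homo sapiens), read by a luciferase reporter and cAMP accumulation, with a stated time of 30 min, at pH 6.8 and pH 8.3, in the presence of a further agent that is not named here (on this read-out higher numbers stand for higher potency (the scale is a negative logarithm) and lower numbers for lower potency), compound 1 gives 4.51, while compound 2 gives 3.97, the lower of the two numbers, and the gap between them lies beyond the usual scatter. Compound 1 and compound 2 differ in more than one place at once, so nothing can be said about which of those changes carries the difference.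

Compound 3 `COc1cccc(CNc2nc(N)nc(-c3ccccc3CO)n2)c1` has not yet been measured. Among the compounds with values here, its only difference from compound 2 is 3-methoxyphenyl in place of 4-fluorophenyl on a saturated chain carbon bound to a nitrogen on an aromatic ring. Within the data shown here, the data hold no measured pair that isolates a change of this kind, so there is no direct guide to its effect. With no evidence pointing either way, the step from compound 2 to compound 3 is expected to be a number 0.13 log units higher from compound 2 to compound 3 (within the scatter), that is, essentially none beyond the scatter. On that basis, compound 3 is estimated to give 4.1, with a likely range from 3.6 to 4.7.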

Compound 3, negative logarithm of the antagonist equilibrium constant: 4.11
The estimate for compound 3 lay 0.01 log units below the measured number; the range from low to high includes it.
By their numbers in this assay, from the lowest: compounds 2 and 3 (each within the scatter of the next); then compound 1.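

In this assay, within the data shown here, putting 3-methoxyphenyl in place of 4-fluorophenyl on a saturated chain carbon bound to a nitrogen on an aromatic ring gives a number 0.14 log units higher from compound 2 to compound 3 (within the scatter), and this is the only measured pair so far that differs in one place. At this position, then, the read-out cannot tell the two groups apart, even though they differ in their substituent, in where it stands on the ring, and in hydrogen-bond acceptors (1 in the entering group, 0 in the leaving one). No measurement at hand bears on why these two groups read alike.

From the compounds shown here alone, compound 1 differs from compound 2 and from compound 3 in more than one place, so those steps cannot be read, and the share of the gap owed to the benzyl part or to the other changed group stays unknown. Going by these compounds, it also remains open whether this position tolerates only substituted phenyl groups of this kind, or whether a carboxylic acid on the ring, an amine on the ring or a longer chain leading to the ring would move the number beyond the scatter.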